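This account rests on a few compounds, and the source may have more. Where it says the series, first, only, none or still open, it means among the compounds named here.

Of the compounds shown here, three sharing one core have been measured in a functional assay on CCRF-CEM cells (Homo sapiens) for antiproliferative activity, read by cell counting, with a stated time of 96 h; a lower number here means a stronger inhibitor, a higher number a weaker inhibitor. Compound 1 (`CC(=O)c1ccc(Oc2ccccc2NC(C)=C2C(=O)CC(c3ccccc3)CC2=O)cc1`) gives 220 nM, compound 2 (`CC(Nc1ccccc1Oc1ccccc1)=C1C(=O)CC(c2ccccc2)CC1=O`) gives 170 nM, and compound 3 (`COc1cc(Oc2ccccc2NC(C)=C2C(=O)CC(c3ccccc3)CC2=O)ccc1N`) gives 12 nM. Compound 3 has the lowest number of the three, and its steps to both others lie beyond the scatter.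

Compound 4 (`CCOc1ccccc1NC(C)=C1C(=O)CC(c2ccccc2)CC1=O`) has ethyl in place of 4-amino-3-methoxyphenyl on an oxygen on an aromatic ring. Measured steps at this same place give some guidance. Both a 14-fold lower number from compound 2 to compound 3 (1.15 log units; beyond the scatter) and an 18-fold lower number from compound 1 to compound 3 (1.26 log units; beyond the scatter) are large, while a 1.3-fold lower number from compound 1 to compound 2 (0.11 log units; within the scatter) stays within the scatter. For the measured compounds named here, the low number so far belongs only to the compound carrying 4-amino-3-methoxyphenyl, and compound 4 gives up that group. Going by the values given here, no measured compound has ethyl at this place, so the size of the change is uncertain. The expected change in this assay is a 33-fold higher number from compound 3 to compound 4 (1.52 log units; beyond the scatter), a large step toward a higher number. The estimate for compound 4 is 400 nM, with an expected range from 110 nM to 2000 nM.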

Compound 4, half-maximal inhibitory concentration: 190 nM
Estimate against measurement, compound 4: 2.1-fold (0.32 log units) above; low and high end bracket the measured number.
By their numbers in this assay, from the lowest: compound 3; then compounds 2, 4 and 1 (each within the scatter of the next).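

In this assay, the step of a 1.1-fold higher number from compound 2 to compound 4 (0.05 log units; within the scatter) lies within the scatter, as does the step of a 1.2-fold lower number from compound 1 to compound 4 (0.06 log units; within the scatter) on the other side, so ethyl, phenyl and 4-acetylphenyl on this oxygen cannot be told apart. Set against the large step of a 16-fold higher number from compound 3 to compound 4 (1.20 log units; beyond the scatter) in this series, this shows that an aromatic ring on the oxygen is not enough for a low number: compounds 1 and 2 carry one yet sit with compound 4, and only 4-amino-3-methoxyphenyl stands apart among these four groups. Nothing measured here gives a reason for this gap.

As far as these compounds go, whether the amino group alone or the methoxy group alone on the phenyl ring would give the low number remains open, as does the effect of a longer chain such as butyl, or of an amine at the end of the ethyl chain.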